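Acetyl to dimethylamino on the pendant phenyl ring

The source may hold more compounds than are shown below. What is called first, only, known or untested is meant among the compounds shown, and "the series" means these compounds.

Measured so far:
- compound 1, `COc1cc(C)cc(-c2c(-c3ccnc(-c4ccc(C(C)=O)cc4)c3)cnn2CC#N)c1`: 43%
- compound 2, `Cc1cc(O)cc(-c2nn(CC#N)cc2-c2ccnc(-c3ccc(N(C)C)cc3)c2)c1`: 44%

In a functional assay on TK-10 cells (Homo sapiens) for cytotoxicity, read by sulforhodamine B assay, with a stated time of 48 h, tested at 1 uM (a higher number here means a weaker effect of the compound at the concentration tested, a lower number a stronger effect), compound 1 gives 43%. Compound 2 gives 44% in this assay, a value that lies within the usual scatter of the value of compound 1, so the two cannot be told apart on these numbers. Within the data shown here, compound 2 differs from compound 1 in more than one place, so no single step between them is counted.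

Compound 3, `COc1cc(C)cc(-c2c(-c3ccnc(-c4ccc(N(C)C)cc4)c3)cnn2CC#N)c1`, is not yet measured. It differs from compound 1 as follows: dimethylamino in place of acetyl on an aromatic carbon. Compound 2 already carries the dimethylamino group and sits at the same level as compound 1, which is the only hint available. No shift beyond the scatter is expected in this assay; the step of a number 1 percentage points higher from compound 1 to compound 3 (within the scatter) is the estimated change. Compound 3 is expected to give about 44%, within a range from 30% to 58%.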

Compound 3, a percentage reported as activity, at one concentration (the size of the read-out at that concentration, not a potency): 31%
Compound 3: middle estimate off by 13 percentage points, on the high side; low and high end bracket the measured number.
By their numbers in this assay, from the lowest: compound 3; then compounds 1 and 2 (each within the scatter of the next).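

In this assay, the 4-acetylphenyl to 4-(dimethylamino)phenyl change gives a number 12 percentage points lower from compound 1 to compound 3 (beyond the scatter), so the read-out responds to the group at this place, on a six-membered aromatic ring of carbon only, para to a large group. Compound 1 and compound 2 differ in more than one place and could not isolate this substituent. The exchange leaves the heavy-atom, donor and acceptor counts unchanged, and the entering group has no double bond outside aromatic rings and carries nitrogen where the leaving group carries oxygen. Nothing available explains the step.

Open, from the compounds shown here alone, is whether a primary amine, a morpholine ring or a carboxylic acid at this place would shift the read-out further. Also open, going by these compounds, is whether the step from acetyl to dimethylamino holds with a hydroxy group in place of the methoxy group.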